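A few compounds are considered here, and "the series" means these few. Any claim that something is new, unique, unknown or untested is made for them only; others in the source may bear on it.

Compound 1 `Cn1c(-c2ccc(NC(=O)CSc3nc4ccccc4o3)cc2)nc(-c2ccccc2)c1-c1ccccc1`: 81.5%
Compound 2 `CCN1CCN(CC(=O)Nc2ccc(-c3nc(-c4ccccc4)c(-c4ccccc4)n3C)cc2)CC1`: 51.2%

Within the data shown here, in a functional assay on HT-29 cells (Homo sapiens) for cytotoxicity, read by MTT assay, with a stated time of 24 h, tested at 80 ug/mL (a lower number here means a weaker effect, a higher number a stronger effect of the compound at the concentration tested), compound 2 stands lowest of the two numbers measured; the single step of a number 30.3 percentage points lower from compound 1 to compound 2 (beyond the scatter) was large. Compound 3 `COc1ccc(CN2CCN(CC(=O)Nc3ccc(-c4nc(-c5ccccc5)c(-c5ccccc5)n4C)cc3)CC2)cc1` differs from compound 2 by 4-methoxyphenyl in place of methyl on a saturated chain carbon bound to an amine nitrogen in a ring. No measured step touches this part of the molecule, so nothing shown bears directly on the change, and no shift beyond the scatter is expected. The step from compound 2 is therefore estimated at a number 3.8 percentage points higher from compound 2 to compound 3 (within the scatter). Compound 3 is expected to give 55%, within a range from 35% to 75%.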

Compound 3, a percentage reported as activity, at one concentration (the size of the read-out at that concentration, not a potency): 51.2%
Compound 3: the middle estimate sits 3.8 percentage points above what was measured, and the stated range covers the measured number.
By their numbers in this assay, from the lowest: compounds 2 and 3 (each within the scatter of the next); then compound 1.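

In this assay swapping ethyl for 4-methoxybenzyl gives no change at the digits printed from compound 2 to compound 3 (within the scatter) at this place, on a saturated chain carbon bound to an amine nitrogen in a ring. So 8 heavy atoms and an aromatic ring replace 1 heavy atom here with no shift in the read-out, something the earlier step, which replaced the whole group on the carbon bound to the carbonyl carbon, could not show. Nothing available explains this outcome.

From the compounds shown here alone, whether this tolerance extends beyond these two groups stays open. A carboxylic acid, a primary amine or a much longer chain at this place could behave differently.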